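The source may report more compounds than this note shows. Statements on the series, on what has been measured and on what is new or still open speak of the compounds shown alone.

Measured compounds:
compound 1, `COc1ccc(N2CCN(c3ccc(C(=O)/C=C/c4ccc(Cl)cc4)cc3)CC2)cc1`: 55.1%
compound 2, `COc1ccccc1N1CCN(c2ccc(C(=O)/C=C/c3ccc(Cl)cc3)cc2)CC1`: 6.13%
compound 3, `COc1cccc(N2CCN(c3ccc(C(=O)/C=C/c4ccc(Cl)cc4)cc3)CC2)c1`: 2.28%

All three were run in a functional assay on the whole organism (strain Kunming) for inhibition, with Mus musculus as the target, with a stated time of 1 h, at a dose of 40 mg/kg by the oral route; on this read-out higher numbers stand for more inhibition at the one dose given (going by the name of the read-out) and lower numbers for less inhibition. Compound 3 gives the lowest of the three numbers; compound 2 lies close to it, the two values being within the scatter, while compound 1 stands far higher (a number 52.8 percentage points lower from compound 1 to compound 3 (beyond the scatter)). The measured steps are a number 49 percentage points lower from compound 1 to compound 2 (beyond the scatter), a number 52.8 percentage points lower from compound 1 to compound 3 (beyond the scatter) and a number 3.9 percentage points lower from compound 2 to compound 3 (within the scatter); each concerns only where the methoxy group sits on the methoxyphenyl carried by the amine nitrogen in the ring.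

Compound 4, `O=C(/C=C/c1ccc(Cl)cc1)c1ccc(N2CCN(S(=O)(=O)c3ccc(Cl)cc3)CC2)cc1`, is not yet measured. Against compound 3 the change is (4-chlorophenyl)sulfonyl in place of 3-methoxyphenyl on an amine nitrogen in a ring. Among the compounds with values here, no measured step involves a group of this kind on the ring nitrogen, so none bears directly on this step; the measured steps show only that small changes at this position can move the read-out strongly. No direction can be derived from the numbers, so the estimate stays near the low values of compound 2 and compound 3 with a wide range. Compound 4 is expected to give 15% (0% to 50%) in this assay. That expectation amounts to a step of a number 12.7 percentage points higher from compound 3 to compound 4 (beyond the scatter), a shift with little support either way.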

Compound 4, a percentage reported as inhibition, in the whole organism at one dose (the size of the read-out at that dose, not a potency): 56.6%
For compound 4 the middle estimate is 41.6 percentage points below the measured one, and the stated range ends below it.
By their numbers in this assay, from the lowest: compounds 3 and 2 (each within the scatter of the next); then compounds 1 and 4 (each within the scatter of the next).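

In this assay, the amine nitrogen in the ring is not confined to a methoxyphenyl group: (4-chlorophenyl)sulfonyl in place of 3-methoxyphenyl gives a number 54.3 percentage points higher from compound 3 to compound 4 (beyond the scatter), and in place of 2-methoxyphenyl it gives a number 50.5 percentage points higher from compound 2 to compound 4 (beyond the scatter). Against 4-methoxyphenyl the same exchange gives a number 1.5 percentage points higher from compound 1 to compound 4 (within the scatter), so two quite different groups on this nitrogen are not separated by this read-out, and the sulfonyl group does not need a particular methoxy placement to match compound 1. Nothing at hand accounts for these steps.

On these data alone, it remains open whether the sulfonyl link or the 4-chlorophenyl ring carries the effect; a 4-chlorophenyl, a benzoyl or a methanesulfonyl group on the same nitrogen would begin to separate the two. The single dose also leaves open how compound 1 and compound 4 would compare at other doses.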